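Aryl Ester Exchange on a Shared Core

The source may report more compounds than this note shows. Statements on the series, on what has been measured and on what is new or still open speak of the compounds shown alone.

Within the data shown here, compound 2 `CC(=O)Oc1ccccc1C(=O)O[C@H]1CO[C@H]2[C@@H]1OC[C@H]2OC(=O)c1ccccc1C` holds the lowest of the two numbers measured so far in an ADME assay on a cell-free system (plasma, Homo sapiens) for metabolic stability, with Plasma (Rattus norvegicus) as the target, read by HPLC, at pH 7.4; on this read-out higher numbers stand for a longer-lived compound and lower numbers for a shorter-lived compound; its nearest neighbour is compound 1 `CC(=O)Oc1ccccc1C(=O)O[C@H]1CO[C@H]2[C@@H]1OC[C@H]2OC(=O)c1ccc(O)cc1`, and the two sit within the scatter of each other. In this assay compound 1 gives 0.0198 h and compound 2 gives 0.0138 h. Among the measured compounds shown here, the single measured step, a 1.4-fold lower number from compound 1 to compound 2 (0.16 log units; within the scatter), is the only one that bears on what follows, as it also exchanges the aryl group on that carbonyl carbon. Compound 3 `CCOc1cc(OCC)cc(C(=O)O[C@@H]2CO[C@H]3[C@@H]2OC[C@@H]3OC(=O)c2ccccc2OC(C)=O)c1` differs from compound 2 by 3,5-diethoxyphenyl in place of 2-methylphenyl on a carbonyl carbon. Because a 1.4-fold lower number from compound 1 to compound 2 (0.16 log units; within the scatter) stayed within the scatter, a change of the same kind at the same carbonyl carbon is expected to give no step beyond the scatter in this assay. Compound 3 is therefore estimated at 0.015 h, within 0.007 h to 0.035 h, corresponding to an expected step of a 1.1-fold higher number from compound 2 to compound 3 (0.04 log units; within the scatter).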

Compound 3, half-life: 0.0283 h
The estimate for compound 3 lay 1.9-fold (0.28 log units) below the measured number; measured number inside the range.
By their numbers in this assay, from the lowest: compounds 2, 1 and 3 (each within the scatter of the next, the first and the last beyond it).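

Among these compounds, at this carbonyl carbon, the choice of aryl group can move the number beyond the scatter in this assay: 3,5-diethoxyphenyl in place of 2-methylphenyl gives a 2.1-fold higher number from compound 2 to compound 3 (0.31 log units; beyond the scatter) and is the first step here to clear the scatter, though only modestly. The same group in place of 4-hydroxyphenyl gives a 1.4-fold higher number from compound 1 to compound 3 (0.16 log units; within the scatter) and does not clear it, so the separation holds against only one of the two earlier aryl groups. Nothing available here accounts for this difference between the two steps.

The compounds shown leave open whether an amine or a carboxylic acid on the phenyl ring, or a longer chain in place of the ethoxy groups, would extend the step. Also open, as far as these compounds go, is whether a single ethoxy group would give the same step as two.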